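The source may report more compounds than this note shows. Statements on the series, on what has been measured and on what is new or still open speak of the compounds shown alone.

In an assay on HepG2 cells for agonist activity at nuclear receptor subfamily 1 group I member 3 (Homo sapiens), read by a luciferase reporter, with a stated time of 23 h (on this read-out lower numbers stand for an effect already at smaller amounts and higher numbers for an effect only at larger amounts of compound), compound 1, with the structure `Cc1ccc(-c2nc3sccn3c2/C=N/OCc2ccc(Cl)c(Cl)c2)cc1`, gives 490 nM. Two companions on a related but not identical core have been measured in the same way. For the measured compounds named here, compound 2, `FC(F)(F)c1ccc(CO/N=C/c2c(-c3ccc4ccccc4c3)nc3occn23)cc1`, gives 470 nM, a number that sits within the usual scatter of the one for compound 1, so the two cannot be told apart. Compound 3, `C(=N/OCc1ccc(Oc2ccccc2)cc1)\c1c(-c2ccc3ccccc3c2)nc2occn12`, is reported as "not active" (no number reported), with no number given at all, so it offers no point of comparison on the scale. Going by the values given here, compound 1 thus stands beside compound 2 among the compounds that have yielded a number, and no single measured pair differs in only one place, so no step between measured compounds can be drawn on.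

The next compound, compound 4, has the structure `CC(C)(C)c1ccc(-c2nc3sccn3c2/C=N/OCc2ccc(Cl)c(Cl)c2)cc1`. It differs from compound 1 in one spot: tert-butyl in place of methyl on an aromatic carbon. A change of this kind, tert-butyl in place of methyl on an aromatic carbon, is small in count and leaves donors, acceptors and charge untouched. Among the compounds with values here, with no measured step to lean on, the expected shift from compound 1 to compound 4 in this assay is a 1.2-fold higher number from compound 1 to compound 4 (0.09 log units; within the scatter), most likely within the scatter and in no clear direction. Compound 4 is therefore estimated at 600 nM, with a range from 200 nM to 2000 nM.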

Compound 4, half-maximal effective concentration: 2400 nM
Compound 4: the middle estimate sits 4.0-fold (0.60 log units) below what was measured; the measured number lies above the stated range.
By their numbers in this assay, from the lowest: compounds 2 and 1 (each within the scatter of the next); then compound 4.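

In this assay, for the compounds shown here, replacing methyl with tert-butyl gives a 4.9-fold higher number from compound 1 to compound 4 (0.69 log units; beyond the scatter), the first step here that joins two measured compounds differing in one place. It shows that this position, on an aromatic carbon para to a large group, is not indifferent to what it carries: moving from 4-methylphenyl to 4-(tert-butyl)phenyl shifts the number beyond the scatter, towards an effect only at larger amounts of compound. No measurement shown here gives a reason for this shift.

Going by these compounds, with only these two groups compared at this position, it remains open whether the number would rise gradually along a series such as ethyl and isopropyl, or whether a different kind of group, such as methoxy, an amine or a carboxylic acid, would move it the other way. On these data alone, it is also open whether the same exchange would have a similar effect on the related core of compound 2 and compound 3, since this single step comes from the core of compound 1 alone.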